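The source may report more compounds than this note shows. Statements on the series, on what has been measured and on what is new or still open speak of the compounds shown alone.

Measured compounds:
compound 1 `Cc1ccc(S(=O)(=O)OC[C@H]2O[C@@H](OCc3noc(-c4ccc([N+](=O)[O-])cc4)n3)[C@@H]3OC4(CCCC4)O[C@@H]32)cc1`, > 100000 nM in a functional assay on HBL-100 cells (Homo sapiens) for antiproliferative activity, read by sulforhodamine B assay, with a stated time of 48 h; on this read-out lower numbers stand for stronger inhibition of growth and higher numbers for weaker inhibition of growth
compound 2 `CC1(C)O[C@H]2[C@H](OCc3noc(-c4ccc([N+](=O)[O-])cc4)n3)O[C@H](CSc3nnc(N)s3)[C@H]2O1`, > 100000 nM in this assay
compound 3 `Clc1ccc(-c2nc(CO[C@@H]3O[C@H](CSc4ncn[nH]4)[C@H]4OC5(CCCC5)O[C@@H]34)no2)cc1`, 24000 nM in this assay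

The value of compound 1 is a limit of this assay, not a number, so its growth inhibition is only known to be weaker than the assay can resolve. The value of compound 2 is likewise a limit. Compound 3 alone gives a number, and it shows only modest inhibition of growth. Compound 1 therefore stands at the weak end of what has been measured, together with compound 2, as the limit of > 100000 nM in this assay, at which 2 of the 3 values shown sit, records.

The unmeasured compound 4 `Nc1nnc(SC[C@H]2O[C@@H](OCc3noc(-c4ccc([N+](=O)[O-])cc4)n3)[C@@H]3OC4(CCCC4)O[C@@H]32)s1` differs from compound 1 in one place: (5-amino-1,3,4-thiadiazol-2-yl)sulfanyl in place of ((4-methylphenyl)sulfonyl)oxy on a saturated chain carbon bound to a saturated ring carbon. Compound 2 carries the same (5-amino-1,3,4-thiadiazol-2-yl)sulfanyl group on a related core and sits at the limit, while compound 3 carries a different sulfanyl group on the same core as compound 4 and gives a number. Among the compounds with values here, no measured pair isolates this change, so the size of the step cannot be read from the data.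

The expectation is that compound 4 will stay weak, with a step from compound 1 of an at least 1.2-fold lower number from compound 1 to compound 4 (0.09 log units; that floor lies within the scatter) that most likely does not go beyond the scatter. Compound 4 is estimated at 80000 nM, ranging from 20000 nM to 300000 nM.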

Compound 4, concentration for 50% growth inhibition: 26000 nM
Estimate against measurement, compound 4: 3.1-fold (0.49 log units) above; the measured number falls inside the stated range.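

In this assay, this position proves responsive: on the saturated chain carbon bound to a saturated ring carbon, (5-amino-1,3,4-thiadiazol-2-yl)sulfanyl in place of ((4-methylphenyl)sulfonyl)oxy brings an at least 3.8-fold lower number from compound 1 to compound 4 (0.58 log units; beyond the scatter). Within the data shown here, the earlier compounds offered no pair that isolated a change here, so this is the first direct sign that the group on this carbon can move growth inhibition, although compound 4, at 26000 nM, remains a weak inhibitor in absolute terms. The step can only be stated as a minimum, because compound 1 sits at a limit of the assay rather than at a number: the limit of > 100000 nM in this assay, at which 2 of the 4 values shown sit.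

What stays open is which part of the entering group accounts for the step, as the ring, the sulfur link and the amino group all arrive together in one change. How a simple amine, a methylsulfanyl group or the same thiadiazole ring without its amino group would read on this carbon in this assay also remains unanswered by the compounds shown.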